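The source may report more compounds than this note shows. Statements on the series, on what has been measured and on what is new or still open speak of the compounds shown alone.

Measured so far in a functional assay on HT-29 cells (Homo sapiens) for inhibition, read by MTT assay, with a stated time of 48 h; a higher number here means a weaker inhibitor, a lower number a stronger inhibitor: compound 1 `Cc1ccc(NC(=O)NC(=O)c2ccc(OCc3ccccc3)cc2)cc1-c1nc2ccccc2[nH]1` gives 16400 nM; compound 2 `Cc1ccc(NC(=O)NC(=O)c2ccc(OCc3cccc(Cl)c3)cc2)cc1-c1nc2ccccc2[nH]1` gives 15400 nM; compound 3 `Cc1ccc(NC(=O)NC(=O)c2ccc(OCc3cccc(Cl)c3Cl)cc2)cc1-c1nc2ccccc2[nH]1` gives 48500 nM.

Compound 3 holds the highest of the three numbers, separated from compound 1 and compound 2 by a 3.0-fold higher number from compound 1 to compound 3 (0.47 log units; beyond the scatter) and a 3.1-fold higher number from compound 2 to compound 3 (0.50 log units; beyond the scatter). Compound 4 `Cc1ccc(NC(=O)NC(=O)c2ccc(OCc3ccccc3Cl)cc2)cc1-c1nc2ccccc2[nH]1` differs from compound 3 by hydrogen in place of chloro on an aromatic carbon. Of the measured steps, a 1.1-fold lower number from compound 1 to compound 2 (0.03 log units; within the scatter) concerns the same chloro and shows nothing beyond the scatter, which suggests that removing it again should leave the number where compound 3 stands; a 3.1-fold higher number from compound 2 to compound 3 (0.50 log units; beyond the scatter) belongs to the chloro that compound 4 keeps. The expected step is therefore a 1.2-fold lower number from compound 3 to compound 4 (0.08 log units; within the scatter), with no change beyond the scatter in this assay. Compound 4 is estimated at 40000 nM, ranging from 15000 nM to 100000 nM.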

Compound 4, half-maximal inhibitory concentration: 9010 nM
The estimate for compound 4 lay 4.4-fold (0.65 log units) above the measured number, and the stated range ends above it.
By their numbers in this assay, from the lowest: compounds 4, 2 and 1 (each within the scatter of the next); then compound 3.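

In this assay the higher number belongs to the 2,3-dichlorobenzyl group of compound 3 and not to either chloro alone, as removing one chloro gives a 5.4-fold lower number from compound 3 to compound 4 (0.73 log units; beyond the scatter), while a 1.8-fold lower number from compound 1 to compound 4 (0.26 log units; within the scatter) and a 1.7-fold lower number from compound 2 to compound 4 (0.23 log units; within the scatter) show the 2-chlorobenzyl group of compound 4 within the scatter of both other compounds. The same chloro change therefore depends on whether the other chloro is present: the same change on two cores in this assay, a 1.1-fold lower number (0.03 log units; within the scatter) from compound 1 to compound 2 and a 5.4-fold higher number (0.73 log units; beyond the scatter) from compound 4 to compound 3, 5.7-fold (0.76 log units) apart, beyond the scatter of two such steps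

The second chloro shows the same dependence: the same change on two cores in this assay, a 3.1-fold higher number (0.50 log units; beyond the scatter) from compound 2 to compound 3 and a 1.8-fold lower number (0.26 log units; within the scatter) from compound 1 to compound 4, 5.7-fold (0.76 log units) apart, beyond the scatter of two such steps

The compounds shown leave open whether this dependence is specific to chloro. A fluoro or methoxy group in either place on the benzyl group could answer that.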